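Replacing chloro with formyl on compound 2

The compounds below may be only part of what the source reports. "The series", "measured", "known", "first", "only" and "open" are said of these compounds alone.

Measured so far in a functional assay on HCT-116 cells (Homo sapiens) for cytotoxicity, read by MTT assay, with a stated time of 48 h; a higher number here means a weaker inhibitor, a lower number a stronger inhibitor
- compound 1 `O=c1c(-c2cc(O)cc(O)c2)cnc2ccccn12` gives 3000 nM
- compound 2 `O=c1cc(-c2ccc(Cl)cc2)nc2ccccn12` gives 2500 nM

Compound 2, at 2500 nM, stands within the scatter of compound 1, at 3000 nM. Compound 3 `O=Cc1ccc(-c2cc(=O)n3ccccc3n2)cc1` keeps the core of compound 2 but has formyl in place of chloro on an aromatic carbon. Among the measured compounds shown here, no measured pair shows this swap, so in this assay no clear direction can be expected, and probably no step beyond the scatter. The estimated step is a 1.3-fold lower number from compound 2 to compound 3 (0.10 log units; within the scatter) here. Compound 3 is expected at 2000 nM, with an estimated range of 700 nM to 6000 nM in repeated measurements.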

Compound 3, half-maximal inhibitory concentration: 3500 nM
Compound 3: middle estimate off by 1.8-fold (0.24 log units), on the low side; low and high end bracket the measured number.
By their numbers in this assay, from the lowest: compounds 2, 1 and 3 (each within the scatter of the next).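

In this assay, among the compounds shown here, the swap of chloro for formyl on this aromatic carbon gives a 1.4-fold higher number from compound 2 to compound 3 (0.15 log units; within the scatter) and forms the first measured pair that differs in one place. At this position, a group bringing a hydrogen-bond acceptor and a double bond therefore leaves the number without a step beyond the scatter. No measured evidence bears on this result. As far as these compounds go, whether an amine or a carboxylic acid on the same carbon would give a step beyond the scatter remains open, as do changes elsewhere on the shared core.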